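Aryl exchange from compound 3 to compound 4

The source may hold more compounds than are shown below. What is called first, only, known or untested is meant among the compounds shown, and "the series" means these compounds.

In a functional assay on PC-3 cells (Homo sapiens) for inhibition, read by sulforhodamine B assay, with a stated time of 48 h, tested at 50 uM (a lower number here means less inhibition of growth, a higher number more inhibition of growth at the concentration tested), compound 1 `COc1ccc([C@@H]2C/C(=N/OCc3cn(-c4ccc(O)cc4)nn3)c3cc(CC=C(C)C)c(OC)cc3O2)cc1` gives 64%, compound 2 `COc1ccc([C@@H]2C/C(=N/OCc3cn(-c4ccc(C#N)cc4)nn3)c3cc(CC=C(C)C)c(OC)cc3O2)cc1` gives 50% and compound 3 `COc1ccc([C@@H]2C/C(=N/OCc3cn(-c4ccc(Cl)cc4C)nn3)c3cc(CC=C(C)C)c(OC)cc3O2)cc1` gives 49%. Compound 3 is the lowest of the three numbers, but it lies within the scatter of compound 2 and clearly under compound 1.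

Compound 4 `COc1ccc([C@@H]2C/C(=N/OCc3cn(-c4cccc(CO)c4)nn3)c3cc(CC=C(C)C)c(OC)cc3O2)cc1` carries 3-(hydroxymethyl)phenyl in place of 4-chloro-2-methylphenyl on an aromatic nitrogen.

Within the data shown here, three measured steps bear on this change. Among the measured compounds shown here, the modest steps of a number 14 percentage points lower from compound 1 to compound 2 (beyond the scatter) and a number 15 percentage points lower from compound 1 to compound 3 (beyond the scatter) both start from the only compound with a hydroxy-bearing aryl group, while the step of a number 1 percentage points lower from compound 2 to compound 3 (within the scatter) shows no separation between the two groups without hydroxy. For the measured compounds named here, compound 4 also has a hydroxy, but as part of hydroxymethyl, and no measured compound carries that group. Only part of the size of the steps from compound 1 is therefore expected to appear, as a rise in this assay. The estimated step is a number 6 percentage points higher from compound 3 to compound 4 (within the scatter). Compound 4 is expected at 55%, with an estimated range of 42% to 68%.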

Compound 4, percent growth inhibition at one concentration: 34%
Beside the measured number, compound 4's estimate is 21 percentage points above it, and the stated range ends above it.
By their numbers in this assay, from the lowest: compound 4; then compounds 3 and 2 (each within the scatter of the next); then compound 1.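

In this assay, a hydroxy group on the aryl ring at this triazole-free reading of the position does not by itself go with a higher number: 3-(hydroxymethyl)phenyl in place of 4-hydroxyphenyl gives a number 30 percentage points lower from compound 1 to compound 4 (beyond the scatter).

Correction to the opening sentence above; the notes should read as follows.

In this assay, an oxygen-bearing group on the aryl ring on the aromatic nitrogen does not by itself go with a higher number: 3-(hydroxymethyl)phenyl in place of 4-hydroxyphenyl gives a number 30 percentage points lower from compound 1 to compound 4 (beyond the scatter). The same group also falls under both aryl groups without hydroxy, with a number 15 percentage points lower from compound 3 to compound 4 (beyond the scatter) and a number 16 percentage points lower from compound 2 to compound 4 (beyond the scatter), so compound 4 stands lowest of the four and the link between hydroxy and a higher number rests on compound 1 alone. Nothing at hand explains this drop.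

As far as these compounds go, whether the lower number follows the hydroxymethyl group itself or the place it holds on the aryl ring stays open, since compound 4 differs from compound 1 in both. From the compounds shown here alone, how an amine or a carboxylic acid on this aryl ring would read also stays open.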